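The source may hold more compounds than are shown below. What is called first, only, known or untested is meant among the compounds shown, and "the series" means these compounds.

In a functional assay on Ehrlich cells (Mus musculus) for cytotoxicity, read by trypan blue exclusion, with a stated time of 48 h (on this read-out lower numbers stand for stronger inhibition and higher numbers for weaker inhibition), two compounds have been measured so far:
compound 1 `Cc1ccccc1OCC(=O)Nc1nc(-c2ccc(Cl)cc2)cs1` gives 63100 nM
compound 2 `CC(C)c1ccccc1OCC(=O)Nc1nc(-c2ccc(Cl)cc2)cs1` gives 49800 nM

Going by the values given here, compound 1 has the higher of the two numbers, but the only measured step, a 1.3-fold lower number from compound 1 to compound 2 (0.10 log units; within the scatter), lies within the scatter. Compound 3 `Cc1ccc(OCC(=O)Nc2nc(-c3ccc(Cl)cc3)cs2)cc1` differs from compound 1 by 4-methylphenyl in place of 2-methylphenyl on an oxygen on a saturated carbon. Among the compounds with values here, no measured step makes this same change; the one step known alters a different part of the molecule and was small. So no step beyond the scatter is expected in this assay, in either direction. Compound 3 is therefore estimated at 60000 nM, with a range from 25000 nM to 150000 nM, which means a 1.1-fold lower number from compound 1 to compound 3 (0.02 log units; within the scatter).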

Compound 3, half-maximal inhibitory concentration: 40100 nM
The estimate for compound 3 lay 1.5-fold (0.18 log units) above the measured number, within the range that was stated.
By their numbers in this assay, from the lowest: compounds 3, 2 and 1 (each within the scatter of the next).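

In this assay 4-methylphenyl in place of 2-methylphenyl on the oxygen gives a 1.6-fold lower number from compound 1 to compound 3 (0.20 log units; within the scatter) and so stays within the scatter. Going by these compounds alone, this is the first reading at this part of the molecule, and here the two methylphenyl groups cannot be told apart by their numbers. No evidence bearing on this result is available.

Going by these compounds, whether a 4-methoxyphenyl or a 4-aminophenyl group in the same place would move the number beyond the scatter remains open. So does the effect of a carboxylic acid or a longer chain there.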